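A few compounds are considered here, and "the series" means these few. Any claim that something is new, unique, unknown or untested is made for them only; others in the source may bear on it.

In a functional assay for inhibition, with Homo sapiens as the target (a lower number here means a stronger inhibitor, a higher number a weaker inhibitor), compound 1 (`O=C(NC[C@H](NS(=O)(=O)c1cccnc1)C(=O)O)c1cc2cc(CC3CCNCC3)sc2s1`) gives 23 nM while compound 2 (`O=C(NC[C@H](NS(=O)(=O)c1ccccc1)C(=O)O)c1cc2cc(CCC3CCNCC3)sc2s1`) gives 8 nM and compound 3 (`O=C(NC[C@H](NS(=O)(=O)c1cccs1)C(=O)O)c1cc2sc(CCC3CCNCC3)cc2s1`) gives 13 nM as its result. Compound 3 lies within the usual scatter of both compound 2 and compound 1, so it cannot be told apart from either. Compound 4 (`CCCCS(=O)(=O)N[C@@H](CNC(=O)c1cc2sc(CCC3CCNCC3)cc2s1)C(=O)O`) differs from compound 3 in one place, with butyl in place of thiophen-2-yl on a sulfonyl sulfur. Going by the values given here, compound 1, compound 2 and compound 3 all carry an aromatic ring on the sulfonyl sulfur, so no measured pair shows this kind of change. The expected step is a 1.4-fold higher number from compound 3 to compound 4 (0.14 log units; within the scatter) towards a slightly weaker inhibitor and probably no larger than the scatter. For compound 4 the expected value is 18 nM within a range from 7 nM to 45 nM in the coming measurement.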

Compound 4, half-maximal inhibitory concentration: 10 nM
The estimate for compound 4 lay 1.8-fold (0.26 log units) above the measured number; the range from low to high includes it.
By their numbers in this assay, from the lowest: compounds 2, 4, 3 and 1 (each within the scatter of the next, the first and the last beyond it).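

In this assay, going by these compounds alone, the step of a 1.3-fold lower number from compound 3 to compound 4 (0.11 log units; within the scatter) gives the first reading of a group without a ring on the sulfonyl sulfur. Butyl can take the place of thiophen-2-yl there with no difference beyond the scatter, so an aromatic ring on this sulfur is not required for a number of this size in this pair. Nothing at hand explains why the two groups read alike. Still open, as far as these compounds go, is how methyl, a longer chain or a chain ending in an amine or a carboxylic acid would read on this sulfur.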